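Working notes: from compound 2 to compound 4

The source may report more compounds than this note shows. Statements on the series, on what has been measured and on what is new or still open speak of the compounds shown alone.

Values in a functional assay on MCF7 cells (Homo sapiens) for cytotoxicity, read by MTT assay, with a stated time of 72 h; on this read-out higher numbers stand for weaker inhibition and lower numbers for stronger inhibition
Compound 1 `COc1cc2ncnc(Nc3ccc(F)c(Cl)c3)c2cc1NC(=O)/C=C/c1ccc(F)cc1Cl` gives "not active" (no number reported)
Compound 2 `COc1ccc(OC)c(/C=C/C(=O)Nc2cc3c(Nc4ccc(F)c(Cl)c4)ncnc3cc2OC)c1` gives 34300 nM
Compound 3 `COc1ccc(/C=C/C(=O)Nc2cc3c(Nc4ccc(F)c(Cl)c4)ncnc3cc2O[C@H]2CCOC2)c(OC)c1` gives 28600 nM

Going by the values given here, only two of the three compounds have a number. Among the compounds with values here, compound 2 at 34300 nM and compound 3 at 28600 nM lie within the scatter of each other, so compound 2 stands level with the only other number in this assay. Compound 1 has no number to compare.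

Compound 4 `COc1ccc(/C=C/C(=O)Nc2cc3c(Nc4ccc(F)c(Cl)c4)ncnc3cc2OC)cc1` has not yet been measured. It carries 4-methoxyphenyl in place of 2,5-dimethoxyphenyl on a double-bonded chain carbon bound to a double-bonded chain carbon. Within the data shown here, no measured pair isolates a change in one place, so the series offers no direct guide to this step. In this assay no step beyond the scatter is expected, and neither direction is favoured. The expected change is a 1.4-fold lower number from compound 2 to compound 4 (0.14 log units; within the scatter). Compound 1 shows that a result without a number remains possible for compound 4. Compound 4 is estimated at 25000 nM, with an expected range from 8000 nM to 70000 nM.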

Compound 4, half-maximal inhibitory concentration: "not active" (no number reported)
No number was reported for compound 4; no gap can be computed for the estimate.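

In this assay, going by these compounds alone, compound 4 gives "not active" (no number reported) and so no step from compound 2 can be read. No measured evidence bears on this result. The compounds shown leave open how 4-methoxyphenyl in place of 2,5-dimethoxyphenyl shifts the read-out in numerical terms.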